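Swapping the aryl end of an enone for a furan ring

The source may hold more compounds than are shown below. What is called first, only, known or untested is meant among the compounds shown, and "the series" means these compounds.

Measured compounds:
- Compound 1, `Cc1nc(NC(=O)c2ccccc2)sc1C(=O)/C=C/c1ccc(Br)cc1`, gives 52.3% in an assay for inhibition of Polyunsaturated fatty acid 5-lipoxygenase (Homo sapiens), read by spectrophotometry, tested at 10 uM, in the presence of a further agent that is not named here; a lower number here means less inhibition, a higher number more inhibition at the concentration tested (going by the name of the read-out).
- Compound 2, `Cc1ccc(/C=C/C(=O)c2sc(NC(=O)c3ccccc3)nc2C)cc1`, gives 75.1% in this assay.

Compound 2 stands highest of the two numbers shown; the nearest is compound 1, and the step of a number 22.8 percentage points higher from compound 1 to compound 2 (beyond the scatter) lies beyond the scatter. For the measured compounds named here, the only change in that step is a methyl in place of bromo on an aromatic carbon, and it shifted the read-out by a modest amount.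

Compound 3, `Cc1nc(NC(=O)c2ccccc2)sc1C(=O)/C=C/c1ccco1`, is not yet measured. It differs from compound 2 by furan-2-yl in place of 4-methylphenyl on a double-bonded chain carbon bound to a double-bonded chain carbon. Going by the values given here, no measured step changes the ring itself, so the one step between compound 1 and compound 2 bears on it only loosely: it shows that altering this end of the molecule can move the read-out beyond the scatter. A modest shift downward toward the level of compound 1 is expected, as a number 15.1 percentage points lower from compound 2 to compound 3 (beyond the scatter), with wide uncertainty. Compound 3 is therefore estimated at 60%, ranging from 35% to 85%.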

Compound 3, a percentage reported as inhibition, at one concentration (the size of the read-out at that concentration, not a potency): 57.2%
Compound 3: middle estimate off by 2.8 percentage points, on the high side, and the stated range covers the measured number.
By their numbers in this assay, from the lowest: compounds 1 and 3 (each within the scatter of the next); then compound 2.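

Exchanging 4-methylphenyl for furan-2-yl, a five-membered aromatic ring with one oxygen, brings a number 17.9 percentage points lower from compound 2 to compound 3 (beyond the scatter) in this assay and shows that the higher reading does not survive a change of the ring itself. Exchanging 4-bromophenyl for the same furan-2-yl ring gives a number 4.9 percentage points higher from compound 1 to compound 3 (within the scatter), so two ends that differ in ring size and hetero atom cannot be told apart in this read-out, and of the three ends only 4-methylphenyl stands clear of the others. Nothing measured here explains this pattern.

As far as these compounds go, it remains open whether the methyl group matters specifically or whether a 4-ethylphenyl or 4-aminophenyl end would read the same. A thiophene or pyridine ring in this place would also show whether furan-2-yl speaks for five-membered or hetero-atom rings more widely.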